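A Methoxy Group on the Anilino Phenyl Ring

The compounds below may be only part of what the source reports. "The series", "measured", "known", "first", "only" and "open" are said of these compounds alone.

Compound 1 `Cc1nc(SCC(=O)Nc2nc(-c3ccc(Cl)cc3)cs2)n(Nc2ccccc2)c1C`: 19800 nM
Compound 2 `Cc1ccc(Nn2c(SCC(=O)Nc3nc(-c4ccccc4)cs3)nc(C)c2C)cc1`: > 100000 nM

Among the measured compounds shown here, in a functional assay on SK-OV-3 cells (Homo sapiens) for antiproliferative activity, read by sulforhodamine B assay, with a stated time of 48 h (on this read-out lower numbers stand for stronger inhibition of growth and higher numbers for weaker inhibition of growth), compound 1 gives 19800 nM, the only plain number among the measured pair. Compound 2 reaches only the assay limit, (the limit of > 100000 nM in this assay, at which 1 of the 2 values shown sits). Compound 3 `COc1ccc(Nn2c(SCC(=O)Nc3nc(-c4ccc(Cl)cc4)cs3)nc(C)c2C)cc1` differs from compound 1 by methoxy in place of hydrogen on an aromatic carbon. For the measured compounds named here, no measured pair isolates this change, so the size of the step rests on expectation alone. The step from compound 1 to compound 3 is estimated at a 2.0-fold higher number from compound 1 to compound 3 (0.31 log units; beyond the scatter), toward weaker growth inhibition and somewhat beyond the usual scatter. Compound 3 is therefore expected at 40000 nM, within a range from 12000 nM to 150000 nM.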

Compound 3, concentration for total growth inhibition: > 100000 nM
Compound 3: a limit, no number; the forecaster's own chance of this, stated with the estimate: 35%; middle value at least 2.5-fold (0.39 log units) away from the limit.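

Methoxy in place of hydrogen on this aromatic carbon, para to a large group, gives an at least 5.0-fold higher number from compound 1 to compound 3 (0.70 log units; beyond the scatter), the first step shown at this position of the anilino ring. In this assay compound 3 gives > 100000 nM, which is a limit of the assay and not a number, and the step therefore fixes only a lower bound on the loss. This limit recurs in the series: the limit of > 100000 nM in this assay, at which 2 of the 3 values shown sit.

Going by these compounds, how far the step truly reaches stays open. So does whether fluorine or a hydroxyl group at this place would keep the growth inhibition of compound 1.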